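Cytotoxicity in the oxadiazoline series: aryl swap at the saturated ring carbon

A few compounds are considered here, and "the series" means these few. Any claim that something is new, unique, unknown or untested is made for them only; others in the source may bear on it.

Compound 3 `CC(=O)N1N=C(c2ccc(-n3c(C)ccc3C)cc2)OC1c1ccc(N(C)C)cc1` is the reference point. In an ADME assay on Vero cells (Chlorocebus sabaeus) for cytotoxicity, read by MTT assay, with a stated time of 72 h (on this read-out higher numbers stand for weaker inhibition and lower numbers for stronger inhibition), compound 3 gives 175000 nM, level with compound 1 `CC(=O)N1N=C(c2ccc(-n3c(C)ccc3C)cc2)OC1c1ccccc1[N+](=O)[O-]`, which in this assay gives 175000 nM. For compound 2 `Cc1ccc(C)n1-c1ccc(C(=O)N/N=C/c2ccc(O)cc2)cc1` this assay gives "not determined" (no result reported), so no result was reported. Among the compounds with values here, the one measured step that bears on the move, no change at the digits printed from compound 1 to compound 3 (within the scatter), exchanged the group on the saturated ring carbon without any shift beyond the scatter. Compound 4 `CC(=O)N1N=C(c2ccc(-n3c(C)ccc3C)cc2)OC1c1ccc(O)cc1` differs from compound 3 by hydroxy in place of dimethylamino on an aromatic carbon. Within the data shown here, with the only relevant step flat, no change beyond the scatter is expected in this assay for the step of no change at the digits printed from compound 3 to compound 4 (within the scatter). Compound 4 is therefore estimated at 175000 nM, with a range of 90000 nM to 300000 nM.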

Compound 4, half-maximal inhibitory concentration: 187000 nM
Beside the measured number, compound 4's estimate is 1.1-fold (0.03 log units) below it; the range from low to high includes it.
By their numbers in this assay, from the lowest: compounds 1, 3 and 4 (each within the scatter of the next).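

Exchanging dimethylamino for hydroxy on an aromatic carbon gives a 1.1-fold higher number from compound 3 to compound 4 (0.03 log units; within the scatter) in this assay, so the series now includes a hydrogen-bond donor at this place with the reading still within the scatter. The wider exchange at the saturated ring carbon gives a 1.1-fold higher number from compound 1 to compound 4 (0.03 log units; within the scatter), which leaves all three aryl groups shown within the scatter of one another. No measured evidence accounts for this flat result.

Still open, as far as these compounds go, is whether a carboxylic acid or a primary amine on that aromatic carbon would give a reading beyond the scatter. Also open, from the compounds shown here alone, is whether an alkyl chain in place of the aryl group at the saturated ring carbon would do so.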